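The source may hold more compounds than are shown below. What is called first, only, known or untested is meant among the compounds shown, and "the series" means these compounds.

Measured compounds:
- Compound 1, `O=C(CCCCCCNCc1ccc(F)cc1)NO`: 1700 nM
- Compound 2, `O=C(CCCCCCN(Cc1ccc2ccccc2c1)Cc1ccc2ccccc2c1)NO`: 5400 nM
- Compound 3, `Cc1cc(CNCCCCCCC(=O)NO)ccc1F`: 2800 nM

All three were tested in an assay on cells for inhibition of histone deacetylase 8 (Homo sapiens), read by fluorescence, with a stated time of 24 h; on this read-out lower numbers stand for stronger inhibition and higher numbers for weaker inhibition. Compound 2 gives the highest number of the three: compared with compound 3 it lies within the scatter, but compared with compound 1 it lies beyond it, so compound 2 inhibits less strongly than compound 1. Compound 2 carries two (naphthalen-2-yl)methyl groups on the amine nitrogen, whereas compound 1 and compound 3 carry a single group there.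

The next compound, compound 4, `O=C(CCCCCCNCc1ccc2ccccc2c1)NO`, is made from compound 2 by one change: hydrogen in place of (naphthalen-2-yl)methyl on an amine nitrogen. Within the data shown here, the only measured step, a 1.6-fold higher number from compound 1 to compound 3 (0.22 log units; within the scatter), concerns a methyl group on an aromatic ring and does not bear on this change. What does bear on it is that both compounds with a single group on the amine nitrogen give lower numbers than compound 2: compound 1 gives 1700 nM, and compound 3 gives 2800 nM.

Compound 4 is therefore expected to show a 2.2-fold lower number from compound 2 to compound 4 (0.33 log units; beyond the scatter), a move toward stronger inhibition in this assay. The estimate for compound 4 is 2500 nM, with a range from 1000 nM to 6500 nM.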

Compound 4, half-maximal inhibitory concentration: 320 nM
Beside the measured number, compound 4's estimate is 7.8-fold (0.89 log units) above it; the whole stated range lies above it.
By their numbers in this assay, from the lowest: compound 4; then compounds 1, 3 and 2 (each within the scatter of the next, the first and the last beyond it).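

In this assay, the amine nitrogen proves to be a sensitive position: hydrogen in place of one (naphthalen-2-yl)methyl group, a loss of 11 heavy atoms, gives a 17-fold lower number from compound 2 to compound 4 (1.23 log units; beyond the scatter). The earlier compounds shown here could not show this, since no pair among them differed at this nitrogen, and this single pair shows that a second (naphthalen-2-yl)methyl group on it goes with much weaker inhibition. Nothing measured here explains why the number falls so far.

This one pair cannot tell whether a smaller second group on the nitrogen, such as methyl or benzyl, would raise the number as much. It also leaves open how a longer chain in the shared core would affect the compound with the single (naphthalen-2-yl)methyl group.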